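A few compounds are considered here, and "the series" means these few. Any claim that something is new, unique, unknown or untested is made for them only; others in the source may bear on it.

Measured compounds:
compound 1 `C=CC(=O)Nc1ccc(-c2nc(Cl)cc(Nc3ccc(C(=O)N(C)C)cc3)n2)cc1` — > 50000 nM
compound 2 `C=CC(=O)Nc1ccc(-c2nc(Cl)cc(Nc3ccc(C(=O)Nc4cc(C)ccc4C)cc3)n2)cc1` — 14900 nM

Compound 1 `C=CC(=O)Nc1ccc(-c2nc(Cl)cc(Nc3ccc(C(=O)N(C)C)cc3)n2)cc1` stands at a limit of the assay: in a functional assay on HL-60 cells (Homo sapiens) for antiproliferative activity, read by MTT assay, with a stated time of 48 h (on this read-out higher numbers stand for weaker inhibition and lower numbers for stronger inhibition), compound 1 gives > 50000 nM, a limit and not a number (the limit of > 50000 nM in this assay, at which 1 of the 2 values shown sits). Compound 2 `C=CC(=O)Nc1ccc(-c2nc(Cl)cc(Nc3ccc(C(=O)Nc4cc(C)ccc4C)cc3)n2)cc1` gives 14900 nM in this assay, and the step of an at least 3.3-fold lower number from compound 1 to compound 2 (0.52 log units; beyond the scatter) is the only measured one that bears here. Compound 3 `C=CC(=O)Nc1ccc(-c2nc(Cl)cc(Nc3ccc(C(=O)Nc4cccc(C)c4)cc3)n2)cc1` differs from compound 1 by (3-methylphenyl)amino in place of dimethylamino on a carbonyl carbon, an arylamino again taking the place of dimethylamino on the carbonyl carbon, so a step of similar size toward a lower number is expected, an at least 3.3-fold lower number from compound 1 to compound 3 (0.52 log units; beyond the scatter). Compound 3 is therefore estimated at 15000 nM, expected between 5000 nM and 50000 nM.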

Compound 3, half-maximal inhibitory concentration: 3660 nM
The estimate for compound 3 lay 4.1-fold (0.61 log units) above the measured number; the whole stated range lies above it.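

In this assay, the two arylamino compounds are not equivalent: a 4.1-fold lower number from compound 2 to compound 3 (0.61 log units; beyond the scatter) shows that the methyl pattern on this ring, and not merely the presence of an arylamino group, changes the number. Replacing dimethylamino on the carbonyl carbon with (3-methylphenyl)amino gives an at least 13-fold lower number from compound 1 to compound 3 (1.13 log units; beyond the scatter), a bound rather than a measured size, as compound 1 stands at a limit: the limit of > 50000 nM in this assay, at which 1 of the 3 values shown sits.

The compounds shown leave open whether the ring needs a methyl at all, and what a methoxy group, a chlorine or a carboxylic acid would do in its place.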